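This account rests on a few compounds, and the source may have more. Where it says the series, first, only, none or still open, it means among the compounds named here.

Measured so far:
compound 1, `CC1=C(C(=O)Nc2ccc(Br)cc2)C(c2ccc(Cl)cc2Cl)N=C(SCc2ccc(F)cc2)N1`: 7.7%
compound 2, `COc1ccc(C2N=C(SCc3cccc(Cl)c3)NC(C)=C2C(=O)Nc2ccc(Br)cc2)cc1`: 7.7%

In a functional assay on the whole organism (artery, strain albino) with Rattus norvegicus as the target, with a stated time of 30 min, at a dose of 10 mg/kg by the oral route (on this read-out lower numbers stand for less inhibition and higher numbers for more inhibition at the one dose given (going by the name of the read-out)), compound 1 gives 7.7%. Compound 2 stands level with it: in this assay compound 2 gives 7.7%, no change from compound 1 at the digits reported, well within the scatter. Compound 3, `COc1ccc(C2N=C(SCc3ccc(F)cc3)NC(C)=C2C(=O)Nc2ccc(Br)cc2)cc1`, has not been measured. It differs from compound 2 in one place: 4-fluorophenyl in place of 3-chlorophenyl on a saturated chain carbon bound to a sulfur. Compound 1 already carries the (4-fluorobenzyl)sulfanyl group, while differing from compound 2 elsewhere, and it shows the same low inhibition as compound 2. Going by the values given here, no step between measured compounds exists to size this change, so the expectation for compound 3 rests on two level values alone. The step of a number 0.3 percentage points higher from compound 2 to compound 3 (within the scatter) is expected to stay within the scatter, in no particular direction. Compound 3 is therefore estimated at 8%, with a range from -2% to 18%.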

Compound 3, a percentage reported as inhibition, in the whole organism at one dose (the size of the read-out at that dose, not a potency): 6.2%
Compound 3: middle estimate off by 1.8 percentage points, on the high side; low and high end bracket the measured number.
By their numbers in this assay, from the lowest: compounds 3, 1 and 2 (each within the scatter of the next).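

In this assay, going by these compounds alone, the exchange of 3-chlorophenyl for 4-fluorophenyl on a saturated chain carbon bound to a sulfur gives a number 1.5 percentage points lower from compound 2 to compound 3 (within the scatter) and so puts a first size on a change at this position, one that does not separate the two compounds. The same compound also makes the saturated ring carbon readable, where 4-methoxyphenyl in place of 2,4-dichlorophenyl gives a number 1.5 percentage points lower from compound 1 to compound 3 (within the scatter) and likewise leaves the inhibition inside the scatter. Nothing at hand bears on why these values sit so close together.

Still open, as far as these compounds go, is whether an amine or a carboxylic acid on the phenyl ring at the saturated chain carbon bound to a sulfur would move the inhibition beyond the scatter. Equally open, from the compounds shown here alone, is whether a plain methyl or a pyridine ring on the saturated ring carbon would do so.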